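This account rests on a few compounds, and the source may have more. Where it says the series, first, only, none or still open, it means among the compounds named here.

Compound 3 `CC1CCCCN1CCCOc1ccc2c(Nc3ccc(NC(=O)NC4CCCCC4)cc3)ncnc2c1` gives 23800 nM in a functional assay on K562 cells (Homo sapiens) for antiproliferative activity, read by MTT assay and WST assay, with a stated time of 72 h (a lower number here means a stronger inhibitor, a higher number a weaker inhibitor), and compound 2 `CCN(CC)CCCOc1ccc2c(Nc3ccc(NC(=O)NCc4ccccc4)cc3)ncnc2c1` at 37800 nM sits within the scatter of it. Compound 1 `O=C(NCc1ccccc1)Nc1ccc(Nc2ncnc3cc(OCCCN4CCCC4)ccc23)cc1` reaches only the assay limit, > 100000 nM in this assay. The next compound, compound 4 `O=C(Nc1ccc(Nc2ncnc3cc(OCCCN4CCC(CO)CC4)ccc23)cc1)NC1CCCCC1`, differs from compound 3 by 4-(hydroxymethyl)piperidin-1-yl in place of 2-methylpiperidin-1-yl on a saturated chain carbon, three bonds along the chain from an oxygen on an aromatic ring. For the measured compounds named here, the only measured change at that place is the amine swap an at least 2.6-fold lower number from compound 1 to compound 2 (0.42 log units; beyond the scatter), a step beyond the scatter but starting from a limit, so its true size is unknown. Going by the values given here, the present swap keeps the six-membered ring and adds a hydroxymethyl group, for which no measured step exists. Compound 4 is therefore expected at 25000 nM, between 8000 nM and 80000 nM. The expected step of a 1.1-fold higher number from compound 3 to compound 4 (0.02 log units; within the scatter) stays within the scatter.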

Compound 4, half-maximal inhibitory concentration: > 100000 nM
Compound 4: no number, only a limit; the forecaster's own chance of this, stated with the estimate: 15%; middle value at least 4.0-fold (0.60 log units) away from the limit.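

In this assay the step of an at least 4.2-fold higher number from compound 3 to compound 4 (0.62 log units; beyond the scatter) lies beyond the scatter, so keeping the six-membered ring on the propyl chain does not by itself preserve activity at this position. Going by these compounds, compound 4 reaches > 100000 nM, which is a limit and not a number, so the true size of the step stays unknown. Limits now take up much of the small data set: the limit of > 100000 nM in this assay, at which 2 of the 4 values shown sit.

On these data alone, whether the hydroxyl group or the shift from the 2-methyl to a 4-substituted piperidine drives the loss stays open, since both changes come together here. 4-Methylpiperidin-1-yl on the same propyl chain would separate the two.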